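Removing a Methyl from an Oxygen Beside the Amide Nitrogen

The compounds below may be only part of what the source reports. "The series", "measured", "known", "first", "only" and "open" are said of these compounds alone.

Among the compounds with values here, compound 1 `CONC(=S)N/N=C1\C(=O)N(CN2CCN(c3ccc(Cl)cc3)CC2)c2ccc(Cl)cc21` holds the lower of the two numbers measured so far in an ADME assay on MT4 cells (Homo sapiens) for cytotoxicity, read by spectrophotometry, with a stated time of 5 days; a lower number here means that less compound is tolerated, a higher number that more compound is tolerated: compound 1 gives 229000 nM. Its only measured partner, compound 2 `CONC(=S)N/N=C1\C(=O)N(CN2CCN(c3ccc(Cl)cc3)CC2)c2ccc(F)cc21`, gives 347000 nM, and the step of a 1.5-fold higher number from compound 1 to compound 2 (0.18 log units; within the scatter) lies within the usual scatter, so these two compounds cannot be separated on how much of them the cells tolerate. Compound 3 `O=C1/C(=N\NC(=S)NO)c2cc(Cl)ccc2N1CN1CCN(c2ccc(Cl)cc2)CC1` is the compound still to be measured in this assay. It differs from compound 1 in one place: hydrogen in place of methyl on an oxygen. Within the data shown here, no measured step touches this oxygen; the single step in hand concerns a halogen on an aromatic carbon and was small. With nothing pointing in either direction, the expectation is no shift beyond the scatter, an estimated step of a 1.0-fold higher number from compound 1 to compound 3 (0.02 log units; within the scatter). Compound 3 is therefore expected to give about 240000 nM, within a range from 100000 nM to 580000 nM.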

Compound 3, half-maximal cytotoxic concentration: 268000 nM
Beside the measured number, compound 3's estimate is 1.1-fold (0.05 log units) below it, and the stated range covers the measured number.
By their numbers in this assay, from the lowest: compounds 1, 3 and 2 (each within the scatter of the next).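

In this assay, hydrogen in place of methyl on an oxygen whose other neighbour is an amide-type nitrogen gives a 1.2-fold higher number from compound 1 to compound 3 (0.07 log units; within the scatter). Within the data shown here, this is the first reading at this oxygen, and it shows that, on the core of compound 1, methoxyamino and hydroxyamino cannot be told apart in how much compound the cells tolerate. No measurement in hand offers an explanation for this result.

The compounds shown leave open whether a longer chain such as ethyl or propyl on this oxygen, or an amine in place of the whole methoxy group, would also stay within the scatter of compound 1. They also leave open whether the same swap from methoxyamino to hydroxyamino would read alike on compound 2, which carries fluoro in place of chloro.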